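The source may report more compounds than this note shows. Statements on the series, on what has been measured and on what is new or still open speak of the compounds shown alone.

For the measured compounds named here, in a physicochemical assay for lipophilicity (a lower number here means a more polar compound, a higher number a more lipophilic compound), compound 1 (`COc1cccc(NC(=O)Nc2ccc3nc(Oc4ccc(F)cc4C(C)O)c(Cc4ccccc4)cc3c2)c1`) gives 6.72 and stands lowest of the two numbers so far, with compound 2 (`COc1ccccc1NC(=S)Nc1ccc2nc(Oc3ccc(F)cc3C(C)O)c(Cc3ccccc3)cc2c1`) at 7.86 as its only neighbour. Compound 3 (`COc1ccccc1NC(=O)Nc1ccc2nc(Oc3ccc(F)cc3C(C)O)c(Cc3ccccc3)cc2c1`) differs from compound 1 in one place: 2-methoxyphenyl in place of 3-methoxyphenyl on an amide-type nitrogen. Going by the values given here, the one measured step (a number 1.14 log units higher from compound 1 to compound 2 (beyond the scatter)) is large, but it also brings in sulfur for oxygen, which compound 3 does not, so it sets no size here. Among the compounds with values here, no measured step isolates this swap. The expected change (a number 0.08 log units higher from compound 1 to compound 3 (within the scatter)) is none beyond the scatter. For compound 3 the estimated value is 6.8 with an expected range (6.4 to 7.2).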

Compound 3, partition coefficient: 6.72
The estimate for compound 3 lay 0.08 log units above the measured number; the measured number falls inside the stated range.
By their numbers in this assay, from the lowest: compounds 1 and 3 (each within the scatter of the next); then compound 2.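

In this assay, 2-methoxyphenyl in place of 3-methoxyphenyl on the amide-type nitrogen shows no shift beyond the scatter (no change at the digits printed from compound 1 to compound 3 (within the scatter)). With 2-methoxyphenyl held constant, oxygen in place of sulfur now stands alone in one step (a number 1.14 log units lower from compound 2 to compound 3 (beyond the scatter)), so the large difference belongs to that exchange and not to the methoxy position. Nothing available gives a reason for either result.

On these data alone, whether the methoxy position stays as silent in the sulfur series remains open. So does the effect of an amine or a carboxylic acid in place of the methoxy group.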